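A few compounds are considered here, and "the series" means these few. Any claim that something is new, unique, unknown or untested is made for them only; others in the source may bear on it.

The compounds in this account share one core and differ only in the group carried on the nitrogen on an aromatic ring. Compound 1 is `CCCNc1nc2cc(-c3ccc(C)cc3)sc2c(=O)[nH]1`. In an ADME assay on HepG2 cells (Homo sapiens) for cytotoxicity, read by MTT assay, with a stated time of 72 h (a lower number here means that less compound is tolerated, a higher number that more compound is tolerated), compound 1 gives only a limit, > 62500 nM, so where it stands is known only as a bound: the limit of > 62500 nM in this assay, at which 1 of the 3 values shown sits. Compound 2 is `CCCCCCCNc1nc2cc(-c3ccc(C)cc3)sc2c(=O)[nH]1`, and in this assay compound 2 gives 6800 nM. Compound 3 is `CCCCCCC(C)Nc1nc2cc(-c3ccc(C)cc3)sc2c(=O)[nH]1`, and in this assay compound 3 gives 19400 nM. Two measured steps begin at compound 1: an at least 9.1-fold lower number from compound 1 to compound 2 (0.96 log units; beyond the scatter) and an at least 3.2-fold lower number from compound 1 to compound 3 (0.50 log units; beyond the scatter). Between the two longer-chain compounds, a 2.9-fold higher number from compound 2 to compound 3 (0.46 log units; beyond the scatter).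

Compound 4 is `Cc1ccc(-c2cc3nc(NC(C)c4ccccc4)[nH]c(=O)c3s2)cc1`, which differs from compound 1 as follows: 1-phenylethyl in place of propyl on a nitrogen on an aromatic ring. The change enlarges the group on that nitrogen, as did the steps to compound 2 and compound 3, both of which carried the number down out of the limit; it also places a methyl on a saturated chain carbon bound to a nitrogen on an aromatic ring, as in compound 3, whose number sits above that of compound 2. The step is therefore expected to run downward, an at least 3.1-fold lower number from compound 1 to compound 4 (0.49 log units; beyond the scatter). For compound 4 in this assay the estimated value is 20000 nM, with a range from 7000 nM to 60000 nM.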

Compound 4, half-maximal cytotoxic concentration: 9200 nM
For compound 4 the middle estimate is 2.2-fold (0.34 log units) above the measured one, and the stated range covers the measured number.
By their numbers in this assay, from the lowest: compounds 2 and 4 (each within the scatter of the next); then compound 3. At a limit, above all of these: compound 1.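

Putting 1-phenylethyl in place of propyl gives an at least 6.7-fold lower number from compound 1 to compound 4 (0.83 log units; beyond the scatter), so a group carrying a six-membered aromatic ring of carbon only, and not just a longer saturated chain, also brings the number down from the limit held by compound 1. Within the branched series, phenyl in place of hexyl gives a 2.1-fold lower number from compound 3 to compound 4 (0.32 log units; beyond the scatter), which shows that this assay separates these two groups on a saturated chain carbon bound to a nitrogen on an aromatic ring. Against the unbranched chain, 1-phenylethyl in place of heptyl gives a 1.4-fold higher number from compound 2 to compound 4 (0.13 log units; within the scatter), so compound 2 and compound 4 cannot be told apart here, and the branching methyl that separated compound 3 from compound 2 does not separate compound 4 from compound 2.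

On these data alone, how a cyclohexyl ring, or a phenyl ring carrying an amine or a carboxylic acid, would read on this nitrogen stays open. The true size of every step from compound 1 also stays open, as compound 1 is held only as a limit: the limit of > 62500 nM in this assay, at which 1 of the 4 values shown sits.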